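Hydroxy for Fluoro at the Cytotoxicity Limit

The compounds below may be only part of what the source reports. "The series", "measured", "known", "first", "only" and "open" are said of these compounds alone.

In a functional assay on HEp-2 cells (Homo sapiens) for cytotoxicity (on this read-out higher numbers stand for weaker inhibition and lower numbers for stronger inhibition), compound 1 (`Nc1nc(N)c2nn(C3O[C@H](CO)[C@@H](O)[C@H]3O)nc2n1`) gives > 75000 nM as a limit of the assay. Compound 2 (`Nc1nc(F)nc2nn(C3O[C@H](CO)[C@@H](O)[C@H]3O)nc12`) gives > 75000 nM as a limit too. Compound 2 thus stands, with compound 1, at the limit of > 75000 nM in this assay, at which 2 of the 2 values shown sit, and has no exact number. Going by the values given here, the one measured step (a step that the two limits leave unreadable from compound 1 to compound 2) gives no size to carry forward. Compound 3 (`Nc1nc(O)nc2nn(C3O[C@H](CO)[C@@H](O)[C@H]3O)nc12`) carries hydroxy in place of fluoro on an aromatic carbon. The estimated step in this assay is a step that the limit leaves unreadable from compound 2 to compound 3 with no clear direction, so none beyond the scatter is expected. Compound 3 is expected near 100000 nM with an estimated range from 50000 nM to 200000 nM and will probably be reported only as a limit.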

Compound 3, half-maximal inhibitory concentration: > 75000 nM
Compound 3: only a limit was reported; the forecaster's own chance of this, stated with the estimate: 85%; the middle value is on the limit's open side.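

No step among compound 1, compound 2 and compound 3 can be read, as all three stand at the same limit: the limit of > 75000 nM in this assay, at which 3 of the 3 values shown sit.

The compounds shown leave open how the amino, fluoro and hydroxy compounds rank in this assay.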